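Positional Bromine Swap on the Aryl Ketone of Compound 2

A few compounds are considered here, and "the series" means these few. Any claim that something is new, unique, unknown or untested is made for them only; others in the source may bear on it.

Measured so far:
compound 1 `COc1cc(-c2nnc3n2NC(c2cccs2)C(C(=O)c2ccccc2)S3)cc(OC)c1OC`: 86300 nM
compound 2 `COc1cc(-c2nnc3n2NC(c2ccco2)C(C(=O)c2cccc(Br)c2)S3)cc(OC)c1OC`: 63900 nM

Of the compounds shown here, two have been measured in a functional assay on PC-3 cells (Homo sapiens) for cytotoxicity, read by MTT assay, with a stated time of 48 h; on this read-out higher numbers stand for weaker inhibition and lower numbers for stronger inhibition. Compound 1 gives 86300 nM in this assay, and compound 2 gives 63900 nM. These two numbers sit within the usual scatter of each other, so neither compound can be set apart from the other on this read-out.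

Compound 3 `COc1cc(-c2nnc3n2NC(c2ccco2)C(C(=O)c2ccc(Br)cc2)S3)cc(OC)c1OC` has not yet been measured. It differs from compound 2 in one place: 4-bromophenyl in place of 3-bromophenyl on a carbonyl carbon. The atoms are the same, joined differently, and the rest of the structure is untouched.

For the measured compounds named here, no step between measured compounds is available to guide the size of this change. With only this to go on, compound 3 is expected to stay close to compound 2, with the estimated step of a 1.1-fold lower number from compound 2 to compound 3 (0.03 log units; within the scatter) lying within the scatter. Compound 3 is therefore estimated at 60000 nM in this assay, with a range from 25000 nM to 150000 nM.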

Compound 3, half-maximal inhibitory concentration: 36400 nM
For compound 3 the middle estimate is 1.6-fold (0.22 log units) above the measured one; the measured number falls inside the stated range.
By their numbers in this assay, from the lowest: compounds 3, 2 and 1 (each within the scatter of the next, the first and the last beyond it).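

In this assay, for the compounds shown here, compound 2 and compound 3 form the first pair that differs in one place, and putting 4-bromophenyl in place of 3-bromophenyl on a carbonyl carbon gives a 1.8-fold lower number from compound 2 to compound 3 (0.24 log units; within the scatter). This step lies within the scatter, so this read-out does not tell the two bromine placements apart, and the swap has no effect that can be read here. Nothing measured at hand bears on the size of this step.

As far as these compounds go, compound 1 has an unsubstituted phenyl on this carbonyl but also differs from compound 2 in a second place, so what the bromine itself contributes remains open. From the compounds shown here alone, it also remains open whether a methoxy group, an amine or a carboxylic acid on this phenyl ring would give a step beyond the scatter.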